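The compounds below may be only part of what the source reports. "The series", "measured", "known", "first", "only" and "open" are said of these compounds alone.

Compound 1 `COC(=O)c1ccccc1OCc1oc(-c2ccccc2OC)nc1C` gives 20200 nM in an assay on cells for antagonist activity at vitamin D3 receptor (Homo sapiens), read by a luciferase reporter; a lower number here means a stronger inhibitor, a higher number a weaker inhibitor.
Compound 2 `COC(=O)c1ccc(OCc2oc(-c3ccccc3OC)nc2C)cc1` gives 17900 nM in this assay.

Of these two numbers compound 2 has the lower one, but its gap to compound 1 lies within the scatter, so the two stand level. The step to compound 3 `COC(=O)c1ccc(OCc2oc(-c3cccc(OC)c3)nc2C)cc1` changes only where the methoxy group sits: 3-methoxyphenyl in place of 2-methoxyphenyl on an aromatic carbon. Among the compounds with values here, no measured pair shows what such a move does here, and both measured compounds are weak. With no guidance pointing either way, the expected step from compound 2 to compound 3 is a 1.1-fold higher number from compound 2 to compound 3 (0.05 log units; within the scatter), within the scatter. Compound 3 is therefore estimated at 20000 nM, with a range of 7000 nM to 60000 nM.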

Compound 3, half-maximal inhibitory concentration: 8890 nM
For compound 3 the middle estimate is 2.2-fold (0.35 log units) above the measured one; the measured number falls inside the stated range.
By their numbers in this assay, from the lowest: compounds 3, 2 and 1 (each within the scatter of the next, the first and the last beyond it).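

With 3-methoxyphenyl in place of 2-methoxyphenyl on the shared core, the result is a 2.0-fold lower number from compound 2 to compound 3 (0.30 log units; within the scatter) in this assay and so the two compounds stand level. Within the data shown here, this is the first reading at this position, and shifting the methoxy group on that phenyl ring does not clearly separate them. No measured information here accounts for this result.

Still open, from the compounds shown here alone, is whether a hydroxyl or an amine on that phenyl ring would give a clearly lower number. Also open, going by these compounds, is what a carboxylic acid in place of the methyl ester would do.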